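This account rests on a few compounds, and the source may have more. Where it says the series, first, only, none or still open, it means among the compounds named here.

Measured compounds:
Compound 1 `CO[C@@H]1CN(CC2Cc3ccccc3C2)CC[C@H]1n1c(C)nc2cc(C)ccc21` gives 90% in a functional assay for antagonist activity at melanin-concentrating hormone receptor 1 (Homo sapiens), read by cAMP accumulation; on this read-out lower numbers stand for smaller maximal responses and higher numbers for larger maximal responses.
Compound 2 `CO[C@@H]1CN(C[C@@H]2Cc3ccc(NC(=O)C(C)C)cc3C2)CC[C@H]1n1c(C)nc2cc(C)ccc21` gives 74% in this assay.
Compound 3 `CO[C@H]1CN(CCCc2cccc(NC(=O)C3CC3)c2)CC[C@@H]1n1c(C)nc2cc(C)ccc21` gives 82% in this assay.

Compound 1 stands highest of the three; compound 3 lies within the scatter of it, compound 2 beyond it. Among the compounds with values here, the one single-place step, a number 16 percentage points lower from compound 1 to compound 2 (beyond the scatter), replaces a ring hydrogen with an (isopropylcarbonyl)amino group.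

Compound 4 `COC(=O)Nc1ccc2c(c1)C[C@@H](CN1CC[C@@H](n3c(C)nc4cc(C)ccc43)[C@H](OC)C1)C2` differs from compound 1 thus: (methoxycarbonyl)amino in place of hydrogen on an aromatic carbon. This resembles the step to compound 2, because a number 16 percentage points lower from compound 1 to compound 2 (beyond the scatter) likewise placed a nitrogen-linked carbonyl group on the aromatic ring, so a modest lowering in this assay is expected, a number 12 percentage points lower from compound 1 to compound 4 (beyond the scatter). For compound 4 the expected efficacy is 78%, estimated within 66% to 90%.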

Compound 4, largest response reached (reported as efficacy), in percent of the reference or control that the assay uses: 81%
Compound 4: middle estimate off by 3 percentage points, on the low side; the range from low to high includes it.
By their numbers in this assay, from the lowest: compounds 2, 4, 3 and 1 (each within the scatter of the next, the first and the last beyond it).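

In this assay, a result of a number 9 percentage points lower from compound 1 to compound 4 (within the scatter) shows that a nitrogen-linked carbonyl group on this aromatic carbon need not shift the maximal response beyond the scatter, unlike a number 16 percentage points lower from compound 1 to compound 2 (beyond the scatter). Even so, compound 2 at 74% and compound 4 at 81% lie within the scatter of each other, so the (isopropylcarbonyl)amino and (methoxycarbonyl)amino groups cannot be told apart here. No evidence is available to explain these results. The compounds shown leave open how a simple amine or a carboxylic acid on this aromatic carbon would behave.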